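Swapping an ether tail for a urea tail

This account rests on a few compounds, and the source may have more. Where it says the series, first, only, none or still open, it means among the compounds named here.

In an ADME assay on cells (Homo sapiens) for cytotoxicity, read by polymerase chain reaction, with a stated time of 3 days (a lower number here means that less compound is tolerated, a higher number that more compound is tolerated), compound 1 `Cc1nc(N)nc(N[C@@H]2C[C@H](CO)[C@@H](O)[C@H]2O)c1-c1nc2ccccc2s1` gives 4000 nM. Compound 2 `Cc1nc(NCCOC(C)C)nc(N[C@@H]2C[C@H](CO)[C@@H](O)[C@H]2O)c1-c1nc2ccccc2s1` gives 8000 nM, which sits at the top of the two numbers shown, although the step of a 2.0-fold higher number from compound 1 to compound 2 (0.30 log units; within the scatter) is within the scatter. Compound 3 `Cc1nc(NCCNC(=O)NC(C)(C)C)nc(N[C@@H]2C[C@H](CO)[C@@H](O)[C@H]2O)c1-c1nc2ccccc2s1` alters the same chain again: ((tert-butyl)carbamoyl)amino in place of isopropoxy on a saturated chain carbon, two bonds along the chain from a nitrogen on an aromatic ring. Among the measured compounds shown here, only one measured step bears on this, and it changed that chain without moving this assay beyond the scatter, so the expected step of no change at the digits printed from compound 2 to compound 3 (within the scatter) is none beyond the scatter. Compound 3 is therefore estimated at 8000 nM, with a range from 3000 nM to 20000 nM.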

Compound 3, half-maximal cytotoxic concentration: > 25000 nM
Compound 3 gave a limit, no number (the forecaster's own chance of this, stated with the estimate: 10%); middle value at least 3.1-fold (0.49 log units) from the limit.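

In this assay, compound 3 gives a limit, not a number: the limit of > 25000 nM in this assay, at which 1 of the 3 values shown sits.

Putting ((tert-butyl)carbamoyl)amino in place of isopropoxy on this chain gives an at least 3.1-fold higher number from compound 2 to compound 3 (0.49 log units; beyond the scatter), and 2-(((tert-butyl)carbamoyl)amino)ethyl in place of hydrogen on the nitrogen gives an at least 6.2-fold higher number from compound 1 to compound 3 (0.79 log units; beyond the scatter). So what sits at the end of this chain can move the tolerated concentration beyond the scatter, which the isopropoxy ending alone did not show.

On these data alone, the true size of these steps stays open, since the limit hides it. So does how a shorter urea ending without tert-butyl, a primary amine, a carboxylic acid or a longer chain would read here.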